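Swapping the carboxy group of compound 3

A few compounds are considered here, and "the series" means these few. Any claim that something is new, unique, unknown or untested is made for them only; others in the source may bear on it.

In a functional assay on NCI-H460 cells (Homo sapiens) for inhibition, with a stated time of 72 h (a lower number here means a stronger inhibitor, a higher number a weaker inhibitor), compound 3 `COc1cc(C(=O)c2ccc3c(ccn3CCC(=O)O)c2)cc(OC)c1OC` shows only a limit (> 10000 nM). Compound 1 `CCCn1ccc2cc(C(=O)c3cc(OC)c(OC)c(OC)c3)ccc21` gives 2000 nM and compound 2 `COc1cc(C(=O)c2ccc3c(ccn3CO)c2)cc(OC)c1OC` gives 39 nM in this assay on the same core. Compound 4 `COc1cc(C(=O)c2ccc3c(ccn3CCN(C)C)c2)cc(OC)c1OC` differs from compound 3 by one group dimethylamino in place of carboxy on a saturated chain carbon, two bonds along the chain from an aromatic nitrogen with dimethylamino in place of carboxy on a saturated chain carbon, two bonds along the chain from an aromatic nitrogen. Two measured steps lead into compound 3, and both go upward: an at least modest one (an at least 5.0-fold higher number from compound 1 to compound 3 (0.69 log units; beyond the scatter)) and a large one (an at least 250-fold higher number from compound 2 to compound 3 (2.40 log units; beyond the scatter)). Neither carries a dimethylamino group, so they guide the estimate only loosely. With the carboxy gone, a modest to large step toward a lower number is expected (an at least 12-fold lower number from compound 3 to compound 4 (1.09 log units; beyond the scatter)). Compound 4 is estimated at 800 nM with 100 nM to 5000 nM as its range.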

Compound 4, half-maximal inhibitory concentration: 5100 nM
Compound 4: middle estimate off by 6.4-fold (0.80 log units), on the low side; the whole stated range lies below it.
By their numbers in this assay, from the lowest: compound 2; then compound 1; then compound 4. At a limit, above all of these: compound 3.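

Compound 3 holds only a limit, so the swap of carboxy for dimethylamino can be read only as an at least 1.9-fold lower number from compound 3 to compound 4 (0.29 log units; that floor lies within the scatter). The dimethylamino group gives no gain over the propyl chain of compound 1, and it stays far from the hydroxy-bearing chain of compound 2: a 2.6-fold higher number from compound 1 to compound 4 (0.41 log units; beyond the scatter), and a 130-fold higher number from compound 2 to compound 4 (2.12 log units; beyond the scatter). Compound 3 is the only compound here without a true number: the limit of > 10000 nM in this assay, at which 1 of the 4 values shown sits.

Going by these compounds, how far compound 3 truly lies from compound 4 stays open. So does whether a primary amine, an amide or a longer chain at this place would come closer to compound 2.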